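The source may report more compounds than this note shows. Statements on the series, on what has been measured and on what is new or still open speak of the compounds shown alone.

Compound 1 `CCCCc1nc2ccc(OC3CCN(C(C)=N)CC3)cc2n1Cc1ccc2ccc(C(=N)N)cc2c1` and compound 2 `CCc1nc2ccc(OC3CCN(C(C)=N)CC3)cc2n1Cc1ccc2ccc(C(=N)N)cc2c1` share one core. In an assay on isolated protein for inhibition of serine protease 1 (Bos taurus) (on this read-out higher numbers stand for weaker inhibition and lower numbers for stronger inhibition), compound 1 gives 5.7 nM, and compound 2 gives 7.7 nM. Compound 2 has the higher of these two numbers, yet the step of a 1.4-fold higher number from compound 1 to compound 2 (0.13 log units; within the scatter) lies within the scatter, so the two cannot be told apart. Compound 3 `CCC(C)c1nc2ccc(OC3CCN(C(C)=N)CC3)cc2n1Cc1ccc2ccc(C(=N)N)cc2c1` carries the change (ethyl in place of hydrogen on a saturated chain carbon bound to an aromatic carbon and a saturated chain carbon); the same difference, cut one bond further out, reads ethyl to sec-butyl. Going by the values given here, only that single measured step bears on this change, and it hardly moved the number, so only a small shift is expected, a 1.4-fold lower number from compound 2 to compound 3 (0.15 log units; within the scatter). Compound 3 is therefore estimated at 5.5 nM, between 2.2 nM and 14 nM.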

Compound 3, inhibition constant: 10 nM
Compound 3: middle estimate off by 1.8-fold (0.26 log units), on the low side; low and high end bracket the measured number.
By their numbers in this assay, from the lowest: compounds 1, 2 and 3 (each within the scatter of the next).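

In this assay the ethyl added on this saturated chain carbon leaves the result within the scatter (a 1.3-fold higher number from compound 2 to compound 3 (0.11 log units; within the scatter)). The same holds for sec-butyl in place of butyl on the aromatic carbon (a 1.8-fold higher number from compound 1 to compound 3 (0.24 log units; within the scatter)), so ethyl, butyl and sec-butyl at this position cannot be told apart here. No measurement at hand offers an explanation for this. The compounds shown leave open whether a carboxylic acid, an amine or a much longer chain at this position would move the number beyond the scatter.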